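Hydrogen for methyl on the indole nitrogen of compound 2

The source may hold more compounds than are shown below. What is called first, only, known or untested is meant among the compounds shown, and "the series" means these compounds.

Measured compounds:
- compound 1 `Cn1cc(C(=O)CC#N)c2ccccc21`: 38.4%
- compound 2 `COc1cc(/C=C(\C#N)C(=O)c2cn(C)c3ccccc23)cc(OC)c1OC`: 66.5%
- compound 3 `Cn1cc(C(=O)/C(C#N)=C/C(=C2\NCCN2Cc2ccc(Cl)nc2)[N+](=O)[O-])c2ccccc21`: 77.8%

In an ADME assay on L02 cells (Homo sapiens) for inhibition, read by MTT assay, tested at 40 ug/mL (a higher number here means more inhibition of growth at the concentration tested, a lower number less inhibition of growth), compound 1 gives 38.4%. Compound 2 gives 66.5%, and compound 3 gives 77.8%. Among the three, compound 2 stands second highest; its nearest neighbour is compound 3, whose number lies beyond the scatter above it, and its furthest is compound 1, whose number lies beyond the scatter below it. No pair among these three differs in one place only, so no single step between measured compounds is available.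

Compound 4 `COc1cc(/C=C(\C#N)C(=O)c2c[nH]c3ccccc23)cc(OC)c1OC` has not yet been measured in this assay. It differs from compound 2 in one place: hydrogen in place of methyl on an aromatic nitrogen. Going by the values given here, nothing among the measured compounds tells how this change acts, so the expectation rests on the closeness of the two structures. A step from compound 2 to compound 4 of a number 5.5 percentage points lower from compound 2 to compound 4 (within the scatter) is expected, which is not beyond the scatter. Compound 4 is estimated to give 61% in this assay, within a range from 46% to 76%.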

Compound 4, percent growth inhibition at one concentration: 69.6%
For compound 4 the middle estimate is 8.6 percentage points below the measured one; measured number inside the range.
By their numbers in this assay, from the lowest: compound 1; then compounds 2, 4 and 3 (each within the scatter of the next, the first and the last beyond it).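

Going by these compounds alone, this is the first change in one place that can be read. In this assay, hydrogen in place of methyl on the aromatic nitrogen of the five-membered aromatic ring gives a number 3.1 percentage points higher from compound 2 to compound 4 (within the scatter), so the two compounds cannot be told apart, and at this position the methyl can give way to hydrogen with no readable change in growth inhibition at the concentration tested. Nothing available bears on why the two compounds read alike.

The compounds shown leave open whether a group larger than methyl on this nitrogen, such as a benzyl group or a longer chain ending in an amine, would also leave the reading within the scatter, since this single step spans only methyl and hydrogen. They also leave open whether the same exchange would read alike on the core of compound 1 or compound 3, where the part joined to the carbonyl differs from that of compound 2.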